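Removing the Ethylsulfonyl Group from Compound 2

This account rests on a few compounds, and the source may have more. Where it says the series, first, only, none or still open, it means among the compounds named here.

Compound 1 `CCS(=O)(=O)Nc1cc(C2CCCCC2)cc2c1CCCC2c1c[nH]cn1`: in an assay on isolated protein for binding affinity to Alpha-1D adrenergic receptor (Rattus norvegicus), read by radioligand binding (a lower number here means a stronger inhibitor, a higher number a weaker inhibitor), compound 1 gives 447 nM.
Compound 2 `CCS(=O)(=O)Nc1cccc2c1CCCC2c1c[nH]cn1`: in this assay compound 2 gives 1070 nM.
Compound 3 `CCS(=O)(=O)Nc1cccc2c1CCCC2CNC`: in this assay compound 3 gives only a limit of the assay, < 10000 nM.

Of the two real numbers, compound 2 stands highest; its nearest neighbour is compound 1, with a 2.4-fold higher number from compound 1 to compound 2 (0.38 log units; beyond the scatter). The other measured step, a step that the limit leaves unreadable from compound 2 to compound 3, cannot be sized because of the limit of < 10000 nM in this assay, at which 1 of the 3 values shown sits.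

Compound 4 `Nc1cccc2c1CCCC2c1c[nH]cn1` differs from compound 2 in one place: hydrogen in place of ethylsulfonyl on a nitrogen on an aromatic ring. Among the measured compounds shown here, neither measured step touches this nitrogen, so nothing measured bears directly on the change; the only guidance is that removing a substituent elsewhere, in compound 1 to compound 2, weakened binding modestly. A weakening is therefore expected in this assay, estimated as a 2.8-fold higher number from compound 2 to compound 4 (0.45 log units; beyond the scatter). Compound 4 is expected to give about 3000 nM, within a range of 800 nM to 12000 nM.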

Compound 4, inhibition constant: 191 nM
The estimate for compound 4 lay 16-fold (1.20 log units) above the measured number, outside the stated range (below it).
By their numbers in this assay, from the lowest: compound 4; then compound 1; then compound 2.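

Replacing ethylsulfonyl with hydrogen on this nitrogen gives, in this assay, a 5.6-fold lower number from compound 2 to compound 4 (0.75 log units; beyond the scatter), so binding to this receptor does not depend on the ethylsulfonyl group. Among the compounds shown here, this is the first readable change at this nitrogen, and losing a group here lowers the number, whereas losing cyclohexyl in the earlier step raised it. Nothing shown explains the stronger binding of compound 4.

Going by these compounds, it remains open whether a small group on this nitrogen, such as methyl or acetyl, would keep that stronger binding. On these data alone, it is also open whether cyclohexyl would lower the number for compound 4 as it does for compound 2.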